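This account rests on a few compounds, and the source may have more. Where it says the series, first, only, none or still open, it means among the compounds named here.

Values in a functional assay on HT-29 cells (Homo sapiens) for antiproliferative activity, read by MTT assay, with a stated time of 72 h; a lower number here means a stronger inhibitor, a higher number a weaker inhibitor:

- compound 1 `Nc1nc(N)c2cc(CSC(=S)N3CCN(C4CCCCC4)CC3)ccc2n1`: 4050 nM
- compound 2 `Nc1nc(N)c2cc(CSC(=S)N3CCN(c4ccccc4)CC3)ccc2n1`: 2760 nM
- compound 3 `Cc1ccc(N2CCN(C(=S)SCc3ccc4nc(N)nc(N)c4c3)CC2)cc1`: 3020 nM

Compound 3, at 3020 nM, lies within the scatter of both other compounds, as shown by a 1.1-fold higher number from compound 2 to compound 3 (0.04 log units; within the scatter) and a 1.3-fold lower number from compound 1 to compound 3 (0.13 log units; within the scatter). The remaining 1.5-fold lower number from compound 1 to compound 2 (0.17 log units; within the scatter) is also within the scatter, so the three values show no order.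

Compound 4 `Cc1ccccc1N1CCN(C(=S)SCc2ccc3nc(N)nc(N)c3c2)CC1` carries 2-methylphenyl in place of 4-methylphenyl on an amine nitrogen in a ring. Going by the values given here, no measured step tests this kind of change directly. The closest evidence is the methyl in place of hydrogen on an aromatic carbon, a 1.1-fold higher number from compound 2 to compound 3 (0.04 log units; within the scatter), which stays within the scatter. Replacing cyclohexyl with either aromatic group also stays within it, in a 1.5-fold lower number from compound 1 to compound 2 (0.17 log units; within the scatter) and a 1.3-fold lower number from compound 1 to compound 3 (0.13 log units; within the scatter).

On that basis, no step beyond the scatter is expected in this assay, and the estimated change is a 1.0-fold lower number from compound 3 to compound 4 (0.00 log units; within the scatter). For compound 4 the expected value is 3000 nM, with an estimated range of 1500 nM to 6000 nM.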

Compound 4, half-maximal inhibitory concentration: 2950 nM
Beside the measured number, compound 4's estimate is 1.0-fold (0.01 log units) above it; low and high end bracket the measured number.
By their numbers in this assay, from the lowest: compounds 2, 4, 3 and 1 (each within the scatter of the next).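

Moving the methyl within the aromatic group on the ring amine nitrogen, with 2-methylphenyl in place of 4-methylphenyl, is a change of position alone, and in this assay it gives no separation (a 1.0-fold lower number from compound 3 to compound 4 (0.01 log units; within the scatter)). The new compound also stays within the scatter of the phenyl compound (a 1.1-fold higher number from compound 2 to compound 4 (0.03 log units; within the scatter)) and of the cyclohexyl compound (a 1.4-fold lower number from compound 1 to compound 4 (0.14 log units; within the scatter)), so neither methyl placement tested here sets a value apart in these four compounds. No measured evidence is available that would explain why these values sit so close together.

On these data alone, it remains open whether a different group on the aromatic ring, such as a carboxylic acid or an amine, would give a step beyond the scatter. A longer chain between the ring amine nitrogen and the aromatic ring is also untested among the compounds shown.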